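The compounds below may be only part of what the source reports. "The series", "measured", "known", "first", "only" and "open" are said of these compounds alone.

Measured so far in a functional assay on MOLT-4 cells (Homo sapiens) for cytotoxicity, read by sulforhodamine B assay, with a stated time of 48 h; a lower number here means a stronger inhibitor of growth, a higher number a weaker inhibitor of growth:
compound 1, `ClCc1ccccc1Cn1cnc2c(Cl)nc(Cl)nc21`, gives 200 nM
compound 2, `ClCc1ccccc1Cn1cnc2c(Cl)ncnc21`, gives 1580 nM
compound 3, `ClCc1ccccc1Cn1cnc2ncnc(Cl)c21`, gives 1650 nM

Compound 1 and compound 2 share a core, and compound 1 carries one more chloro group; the difference is chloro in place of hydrogen on an aromatic carbon. That single change produced the step of a 7.9-fold lower number from compound 2 to compound 1 (0.90 log units; beyond the scatter). Compound 3 is built from the same atoms as compound 2, joined differently; the difference between the two cores is not broken down here, and in this assay compound 3 and compound 2 give numbers that lie within the scatter of each other. Compound 4, `ClCc1ccccc1Cn1cnc2nc(Cl)nc(Cl)c21`, is compound 3 with the same change applied: chloro in place of hydrogen on an aromatic carbon. The surroundings of the entering chloro group are described in the same words for both pairs, so this is the same change made on a differently joined core. For the measured compounds named here, because the earlier step of a 7.9-fold lower number from compound 2 to compound 1 (0.90 log units; beyond the scatter) was a modest gain beyond the scatter, a step of similar size is expected here, a 6.6-fold lower number from compound 3 to compound 4 (0.82 log units; beyond the scatter), though only one earlier example supports it. Compound 4 is therefore estimated at 250 nM, with a range from 80 nM to 800 nM.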

Compound 4, concentration for 50% growth inhibition: 1340 nM
For compound 4 the middle estimate is 5.4-fold (0.73 log units) below the measured one, outside the stated range (above it).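

In this assay, putting a chloro group in place of hydrogen on the core of compound 3 gives a 1.2-fold lower number from compound 3 to compound 4 (0.09 log units; within the scatter), so on this core the change has no effect that can be told apart from the ordinary spread of repeated measurements. The gain seen on the first core therefore did not carry over to the second, even though the chloro group enters between two ring nitrogen atoms in both pairs: the same change on two cores in this assay, a 7.9-fold lower number (0.90 log units; beyond the scatter) from compound 2 to compound 1 and a 1.2-fold lower number (0.09 log units; within the scatter) from compound 3 to compound 4, 6.4-fold (0.81 log units) apart, beyond the scatter of two such steps

This shows that the size of the step depends on the core in this series, so a result from one core cannot be assumed to hold on the other, but it does not show what in the cores causes the difference, and two pairs cannot establish a general rule.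

The compounds shown leave open how other groups would behave at this place. An amine or a methoxy group in place of the chloro group might differ between the two cores in the same way, or might not.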